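This account rests on a few compounds, and the source may have more. Where it says the series, first, only, none or still open, it means among the compounds named here.

Measured so far in a functional assay on MCF7 cells (Homo sapiens) for inhibition, with a stated time of 96 h; a higher number here means a weaker inhibitor, a lower number a stronger inhibitor:
- Compound 1 `COc1cc(C(=O)c2cn(-c3ccc(F)cc3)cc2-c2ccoc2)cc(OC)c1OC`: 15 nM
- Compound 2 `COc1cc(C(=O)c2cn(-c3ccc(C)cc3)cc2-c2ccncc2)cc(OC)c1OC`: 9 nM
- Compound 3 `COc1cc(C(=O)c2cn(-c3ccc(F)cc3)cc2-c2ccccn2)cc(OC)c1OC`: 73 nM

Compound 3 has the highest number of the three, which makes it the weakest inhibitor here. Compound 4 `COc1cc(C(=O)c2cn(-c3ccc(F)cc3)cc2-c2ccncc2)cc(OC)c1OC` has pyridin-4-yl in place of pyridin-2-yl on an aromatic carbon. Going by the values given here, the one measured step at this place is a 4.9-fold higher number from compound 1 to compound 3 (0.69 log units; beyond the scatter), with pyridin-2-yl in place of furan-3-yl, so changes here can matter. Compound 2 also carries pyridin-4-yl, with a different group elsewhere, and compound 2 gives 9 nM. A clear drop in this assay is therefore expected. The expected change is a 4.9-fold lower number from compound 3 to compound 4 (0.69 log units; beyond the scatter). Compound 4 is estimated at 15 nM, with an expected range of 6 nM to 40 nM.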

Compound 4, half-maximal inhibitory concentration: 9 nM
Beside the measured number, compound 4's estimate is 1.7-fold (0.22 log units) above it; the measured number falls inside the stated range.
By their numbers in this assay, from the lowest: compounds 2, 4 and 1 (each within the scatter of the next); then compound 3.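

In this assay pyridin-4-yl in place of pyridin-2-yl, the same atoms joined differently, gives a large difference (an 8.1-fold lower number from compound 3 to compound 4 (0.91 log units; beyond the scatter)), so how this group is joined matters at this position. With pyridin-4-yl present, fluoro in place of methyl shows no difference (no change at the digits printed from compound 2 to compound 4 (within the scatter)), and furan-3-yl and pyridin-4-yl also read alike (a 1.7-fold lower number from compound 1 to compound 4 (0.22 log units; within the scatter)). Nothing measured here explains the gap between the two pyridine groups. As far as these compounds go, whether pyridin-3-yl or an aminophenyl group at this position would match pyridin-4-yl or pyridin-2-yl stays open.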